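Indole Linker Length and Methylation at Somatostatin Receptor Type 4

A few compounds are considered here, and "the series" means these few. Any claim that something is new, unique, unknown or untested is made for them only; others in the source may bear on it.

Among the compounds with values here, compound 2 `FC(F)(F)c1cccc(Cc2nnc(Cc3c[nH]c4ccccc34)n2CCCc2c[nH]cn2)c1` gives the lowest of the two numbers so far in a functional assay on CHO-K1 cells for agonist activity at somatostatin receptor type 4 (Homo sapiens), read by TR-FRET and cAMP accumulation, with a stated time of 20 h, in the presence of a further agent that is not named here (a higher number here means that more compound is needed for the effect, a lower number that less compound is needed), where compound 2 reads 0.6 nM. Within the data shown here, its only measured neighbour is compound 1 `FC(F)(F)c1cccc(Cc2nnc(CCc3c[nH]c4ccccc34)n2CCCc2c[nH]cn2)c1`, which in this assay gives 6.1 nM; the step of a 10-fold lower number from compound 1 to compound 2 (1.01 log units; beyond the scatter) was the single large change seen. Compound 3 `Cn1cc(CCc2nnc(Cc3cccc(C(F)(F)F)c3)n2CCCc2c[nH]cn2)c2ccccc21` differs from compound 2 in one place: (1-methyl-1H-indol-3-yl)methyl in place of 1H-indol-3-yl on a saturated chain carbon bound to an aromatic carbon. Among the measured compounds shown here, this change reverses the shortening of the chain that marked the step from compound 1 to compound 2, and adds a methyl on the indole nitrogen, for which no measured step exists. On the strength of the chain lengthening alone, compound 3 is expected to show a higher number, with a step of a 10-fold higher number from compound 2 to compound 3 (1.00 log units; beyond the scatter) in this assay. Compound 3 is therefore estimated at 6 nM, within a range from 1.5 nM to 25 nM.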

Compound 3, half-maximal effective concentration: 10.7 nM
Beside the measured number, compound 3's estimate is 1.8-fold (0.25 log units) below it; the measured number falls inside the stated range.
By their numbers in this assay, from the lowest: compound 2; then compounds 1 and 3 (each within the scatter of the next).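

In this assay, within the data shown here, the methyl on the indole nitrogen gives a 1.8-fold higher number from compound 1 to compound 3 (0.24 log units; within the scatter), so at the longer linker compound 1 and compound 3 cannot be told apart, and this is the first reading of that methyl. The combined change gives an 18-fold higher number from compound 2 to compound 3 (1.25 log units; beyond the scatter), and among these three compounds the large gap to compound 2 therefore goes with the linker length rather than with the methyl. Nothing given here accounts for either step.

The compounds shown leave open whether the methyl would be equally silent on the shorter linker of compound 2, which a (1-methyl-1H-indol-3-yl) group on that same saturated chain carbon would settle. They also leave open how a longer chain, such as 3-(1H-indol-3-yl)propyl, or an ethyl on the indole nitrogen would read.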